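The compounds below may be only part of what the source reports. "The series", "measured", "known", "first", "only" and "open" are said of these compounds alone.

Measured compounds in an assay on HEK293 cells for inhibition of Monoacylglycerol lipase ABHD6 (Homo sapiens), read by scintillation counting, with stated times of 30 min and 5 min; on this read-out lower numbers stand for stronger inhibition and higher numbers for weaker inhibition:
- compound 1 `Cc1c(Br)cc(C(=O)NC2CCCCCC2)c(=O)n1Cc1ccc(F)cc1`, compound 1 gives > 10000 nM
- compound 2 `COc1ccc(-c2cc(C(=O)NC3CCCCCC3)c(OCc3ccc(F)cc3)nc2C)cc1`, compound 2 gives 530 nM
- compound 3 `Cc1nc(OCc2ccc(F)cc2)c(C(=O)NC2CCCCCC2)cc1-c1ccc(F)cc1`, compound 3 gives > 10000 nM

The values for compound 1 and compound 3 are limits of the assay and not numbers; each means only that no inhibition strong enough to be measured was seen. Among the compounds with values here, compound 2 is the only one with a measured number. Within the data shown here, the single one-place step among the measured compounds is an at least 18-fold higher number from compound 2 to compound 3 (1.27 log units; beyond the scatter), so the replacement of methoxy by fluoro on the pendant ring turned a measured number into a limit, where (the limit of > 10000 nM in this assay, at which 2 of the 3 values shown sit).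

Compound 4 `Cc1nc(OCc2ccc(F)cc2)c(C(=O)NC2CCCCCC2)cc1Br` shares the core of compound 3 and differs in one place: bromo in place of 4-fluorophenyl on an aromatic carbon. Among the measured compounds shown here, compound 1 also carries bromo at a matching position, on a different core, and its value in this assay is a limit; no step connecting compound 1 to compound 3 or compound 4 is given, so its value can only be read as what it shows. For the measured compounds named here, the one measured step points to a loss when the methoxyphenyl group is altered, and compound 3 already sits at the limit, so no gain beyond the scatter is expected from compound 3 to compound 4, with a step that the limit leaves unreadable from compound 3 to compound 4. Compound 4 is therefore expected to give about 15000 nM, between 4000 nM and 60000 nM, most likely reported again as a limit.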

Compound 4, half-maximal inhibitory concentration: > 10000 nM
Compound 4 ended at the assay's limit; the forecaster's own chance of this, stated with the estimate: 70%; the middle value does not contradict the limit.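

On the aromatic carbon para to the (4-fluorobenzyl)oxy group, this assay now records a second large loss: bromo in place of 4-methoxyphenyl gives an at least 18-fold higher number from compound 2 to compound 4 (1.27 log units; beyond the scatter). Within the data shown here, the earlier step, an at least 18-fold higher number from compound 2 to compound 3 (1.27 log units; beyond the scatter), changed only the group carried on the attached ring, whereas this change removes that ring altogether, so among the three compounds on the shared core, only the one with 4-methoxyphenyl at this position gives a measured number. The values of compound 3 and compound 4 are both limits, so the step between them cannot be read and neither bromo nor 4-fluorophenyl can be ranked over the other: the limit of > 10000 nM in this assay, at which 3 of the 4 values shown sit.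

The compounds shown leave open whether the methoxy group itself matters, or whether an unsubstituted phenyl, a 4-hydroxyphenyl or a 4-ethoxyphenyl group at this carbon would also give a measured number. Also open, from the compounds shown here alone, is what an amine or a carboxylic acid would do at this carbon, and whether any group there can improve on compound 2, which gives 530 nM.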